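The source may hold more compounds than are shown below. What is called first, only, known or untested is meant among the compounds shown, and "the series" means these compounds.

Measured so far:
Compound 1 `Cc1nn(-c2ccccn2)c2cc(-c3ccc(CCC(=O)O)cc3)ccc12` gives 1400 nM in a functional assay on cells for agonist activity at Free fatty acid receptor 1 (Mus musculus), read by FLIPR and calcium flux, with a stated time of 5 min; on this read-out lower numbers stand for an effect already at smaller amounts and higher numbers for an effect only at larger amounts of compound.
Compound 2 `O=C(O)CCc1ccc(-c2ccc3cnn(-c4ccccn4)c3c2)cc1` gives 4500 nM in this assay.
Compound 3 `N#Cc1nn(-c2ccccn2)c2cc(-c3ccc(CCC(=O)O)cc3)ccc12` gives 2000 nM in this assay.

Among these three, compound 2 shows the highest number in this assay, meaning it needs the largest amount of compound to act: the nearest is compound 3 (a 2.3-fold lower number from compound 2 to compound 3 (0.35 log units; beyond the scatter)), the furthest compound 1 (a 3.2-fold higher number from compound 1 to compound 2 (0.51 log units; beyond the scatter)). Compound 4 `N#Cc1cc(-c2ccc(CCC(=O)O)cc2)cc2c1cnn2-c1ccccn1` is not yet measured. It differs from compound 2 in one place: cyano in place of hydrogen on an aromatic carbon.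

Going by the values given here, of the measured steps, the closest parallel is the one from compound 2 to compound 3, where the same kind of exchange, though on a different ring of the shared core, gave a 2.3-fold lower number from compound 2 to compound 3 (0.35 log units; beyond the scatter). The comparison of compound 1 with compound 3 (a 1.4-fold higher number from compound 1 to compound 3 (0.15 log units; within the scatter)) shows that a cyano and a methyl at that other position behave alike. Among the compounds with values here, the new position has no direct precedent among the measured compounds. A step of similar size but uncertain direction is therefore expected for compound 4 in this assay, estimated as a 1.5-fold lower number from compound 2 to compound 4 (0.18 log units; within the scatter). Compound 4 is therefore expected to give about 3000 nM, within a range of 1000 nM to 9000 nM.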

Compound 4, half-maximal effective concentration: 19000 nM
For compound 4 the middle estimate is 6.3-fold (0.80 log units) below the measured one; measured number above the stated range.
By their numbers in this assay, from the lowest: compounds 1 and 3 (each within the scatter of the next); then compound 2; then compound 4.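

In this assay cyano in place of hydrogen on this aromatic carbon, on the six-membered ring of carbon only, moves the number up (a 4.2-fold higher number from compound 2 to compound 4 (0.63 log units; beyond the scatter)), whereas the same exchange on a different ring of the shared core moved it down (a 2.3-fold lower number from compound 2 to compound 3 (0.35 log units; beyond the scatter)). Going by these compounds alone, the earlier compounds varied only that other position, so this pair is the first to show that the same group on the same core can shift the result in opposite directions depending on where it sits. Nothing available here offers an explanation for this difference.

Going by these compounds, what remains open is whether the higher number belongs to cyano specifically or would follow any group placed here. A fluorine atom, a methoxy group or an amine at this position would help separate these two possibilities.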